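The source may hold more compounds than are shown below. What is called first, only, known or untested is meant among the compounds shown, and "the series" means these compounds.

Measured in a functional assay on A549 cells (Homo sapiens) for cytotoxicity, read by MTT assay, with a stated time of 72 h; a higher number here means a weaker inhibitor, a lower number a stronger inhibitor:
- Compound 1 `O=C(N/N=C/c1ccc(Br)cc1)N1CCc2ncnc(Nc3ccc(F)c(Cl)c3)c2C1`: 14100 nM
- Compound 2 `O=C(N/N=C/c1cccc([N+](=O)[O-])c1)N1CCc2ncnc(Nc3ccc(F)c(Cl)c3)c2C1`: 43100 nM
- Compound 3 `O=C(N/N=C/c1ccc(F)cc1)N1CCc2ncnc(Nc3ccc(F)c(Cl)c3)c2C1`: 11400 nM

Compound 2 holds the highest number of the three, and both of its steps lie beyond the scatter. Compound 4 `O=C(N/N=C/c1ccc(C(F)(F)F)cc1)N1CCc2ncnc(Nc3ccc(F)c(Cl)c3)c2C1` is unmeasured. Its change from compound 2 is 4-(trifluoromethyl)phenyl in place of 3-nitrophenyl on a carbon with a double bond to nitrogen, with 4-(trifluoromethyl)phenyl in place of 3-nitrophenyl on a carbon with a double bond to nitrogen.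

Two measured steps swap the same 3-nitrophenyl for another 4-substituted phenyl: a 3.1-fold higher number from compound 1 to compound 2 (0.49 log units; beyond the scatter) and a 3.8-fold lower number from compound 2 to compound 3 (0.58 log units; beyond the scatter). The bromo-to-fluoro swap is small, a 1.2-fold lower number from compound 1 to compound 3 (0.09 log units; within the scatter). A modest drop of similar size is therefore expected, a 3.3-fold lower number from compound 2 to compound 4 (0.52 log units; beyond the scatter). Compound 4 is estimated at 13000 nM, with an expected range of 6000 nM to 28000 nM.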

Compound 4, half-maximal inhibitory concentration: 37800 nM
Compound 4: the middle estimate sits 2.9-fold (0.46 log units) below what was measured, and the stated range ends below it.
By their numbers in this assay, from the lowest: compounds 3 and 1 (each within the scatter of the next); then compounds 4 and 2 (each within the scatter of the next).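

In this assay a 4-substituent on this phenyl does not by itself give the lower numbers, as 4-(trifluoromethyl)phenyl in place of 3-nitrophenyl shows a 1.1-fold lower number from compound 2 to compound 4 (0.06 log units; within the scatter) and so stays level with the nitro compound. On the aromatic carbon, trifluoromethyl stands apart from both halogens, with a 3.3-fold higher number from compound 3 to compound 4 (0.52 log units; beyond the scatter) and a 2.7-fold higher number from compound 1 to compound 4 (0.43 log units; beyond the scatter) while fluoro and bromo do not separate from each other. No measurement at hand accounts for this split.

On these data alone, whether an amine or a carboxylic acid on this phenyl would group with compound 1 and compound 3 or with compound 2 and compound 4 remains open.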